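Furan-2-ylmethyl variant of the shared core: lipophilicity estimate

The source may report more compounds than this note shows. Statements on the series, on what has been measured and on what is new or still open speak of the compounds shown alone.

Working notes on three measured compounds and one open one, all on the shared core. Compound 1 `CCCCN(C1=NCCN1)c1c(Br)cccc1Br` gives in a physicochemical assay for lipophilicity (a higher number here means a more lipophilic compound, a lower number a more polar compound), a value of -2.5, the lowest of the three numbers; nearest to it is compound 2 `CC(C)N(C1=NCCN1)c1c(Br)cccc1Br` with -0.82, furthest compound 3 `Brc1cccc(Br)c1N(CC1CCCC1)C1=NCCN1` with 0.32. The two measured steps out of compound 1 both rise well beyond the scatter: a number 1.68 log units higher from compound 1 to compound 2 (beyond the scatter) and a number 2.82 log units higher from compound 1 to compound 3 (beyond the scatter); between the other two, a number 1.14 log units higher from compound 2 to compound 3 (beyond the scatter).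

Compound 4 `Brc1cccc(Br)c1N(Cc1ccco1)C1=NCCN1` differs from compound 1 by furan-2-yl in place of propyl on a saturated chain carbon bound to a nitrogen on an aromatic ring. Among the compounds with values here, the step that bears most directly on it is the one from compound 1 to compound 3, which also replaced propyl on the saturated chain carbon bound to the nitrogen on the aromatic ring with a ring, and gave a large rise. The step from compound 1 to compound 2 also rose. A rise in this assay is therefore expected for compound 4, estimated at a number 1.50 log units higher from compound 1 to compound 4 (beyond the scatter), smaller than the cyclopentyl case. The entering group carries a hydrogen-bond acceptor, a feature absent from all three measured compounds; for that reason the expected rise is kept below the step of a number 2.82 log units higher from compound 1 to compound 3 (beyond the scatter). Compound 4 is thus estimated at -1, within -2.3 to 0.3.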

Compound 4, distribution coefficient: -0.52
The estimate for compound 4 lay 0.48 log units below the measured number; the range from low to high includes it.
By their numbers in this assay, from the lowest: compound 1; then compounds 2 and 4 (each within the scatter of the next); then compound 3.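

In this assay the rise at this place, on a saturated chain carbon bound to a nitrogen on an aromatic ring, is not confined to the cyclopentyl case: furan-2-yl in place of propyl gives a number 1.98 log units higher from compound 1 to compound 4 (beyond the scatter) and so a five-membered aromatic ring with a hetero atom also stands well above propyl. The two rings are nevertheless separated, with a number 0.84 log units lower from compound 3 to compound 4 (beyond the scatter) for the exchange of cyclopentyl for furan-2-yl, whereas a number 0.30 log units higher from compound 2 to compound 4 (within the scatter) gives (furan-2-yl)methyl and isopropyl no order in this assay. No measurement at hand accounts for any of these steps.

Phenyl and tetrahydrofuran-2-yl at this place would show whether the gap between the two rings goes with the ring oxygen or with the aromatic ring. As far as these compounds go, how a longer chain such as pentyl stands against propyl also remains open.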